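The source may report more compounds than this note shows. Statements on the series, on what has been measured and on what is new or still open speak of the compounds shown alone.

- compound 1 `CCCC(Oc1ccc(-n2cc(OC)cn2)cc1)c1ccc(C(=O)NCCC(=O)O)cc1` measured at 1.4
- compound 2 `CCCC(Oc1ccc(-n2cccn2)cc1)c1ccc(C(=O)NCCC(=O)O)cc1` measured at 1.7

In a physicochemical assay for lipophilicity, using the shake flask method, at pH 7.4 (a lower number here means a more polar compound, a higher number a more lipophilic compound), compound 2 stands at 1.7 and compound 1 at 1.4 on the same scale. Within the data shown here, these are the only two numbers so far, and they lie within the usual scatter of each other. Compound 3 `CCCC(Oc1ccc(-n2cc(C)cn2)cc1)c1ccc(C(=O)NCCC(=O)O)cc1` has not yet been measured. It carries methyl in place of hydrogen on an aromatic carbon of compound 2, a change counted as methyl in place of hydrogen on an aromatic carbon in full. Among the measured compounds shown here, one measured step bears on it, at that same aromatic carbon: a number 0.30 log units higher from compound 1 to compound 2 (within the scatter) with hydrogen in place of methoxy. That step involves a different group and is only a weak guide. For the measured compounds named here, no measurement yet shows a methyl step here, so the expectation in this assay is a modest upward one, with a number 0.30 log units higher from compound 2 to compound 3 (within the scatter) as the expected step. The estimate for compound 3 is 2 with an expected range from 1.7 to 2.3 for the measurement.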

Compound 3, distribution coefficient: 2.1
Estimate against measurement, compound 3: 0.10 log units below; measured number inside the range.
By their numbers in this assay, from the lowest: compounds 1 and 2 (each within the scatter of the next); then compound 3.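

In this assay, among these compounds, methyl on this aromatic carbon of the five-membered ring gives a number 0.40 log units higher from compound 2 to compound 3 (beyond the scatter) and is the first change here to lie beyond the scatter, whereas hydrogen and methoxy at the same carbon could not be told apart. Set against methoxy, methyl gives a number 0.70 log units higher from compound 1 to compound 3 (beyond the scatter) and this is the widest gap among the three compounds, so these two groups do read apart at this carbon. Nothing measured here offers an explanation for these differences.

The compounds shown leave open whether a longer chain such as ethyl would carry the number further up, and where a chlorine atom or an amine at this carbon would fall on the same scale. They also leave open whether methyl on another carbon of the ring would give a similar step.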